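Dimethylamino replacing imidazolyl on the pyrazole series

The source may hold more compounds than are shown below. What is called first, only, known or untested is meant among the compounds shown, and "the series" means these compounds.

Compound 3 `Cc1nn(C)c(-n2ccnc2)c1/C=N/OCc1ccc(C(=O)OC(C)(C)C)cc1` gives 5.93 ug/mL in a functional assay on A549 cells (Homo sapiens) for cytotoxicity (a higher number here means a weaker inhibitor, a lower number a stronger inhibitor), and stands highest of the three numbers measured. Compound 1 `Cc1nn(C)c(-n2cccc2)c1/C=N/OCc1ccc(C(=O)OC(C)(C)C)cc1` gives 1.64 ug/mL, and compound 2 `Cc1nn(C)c(Oc2ccc(Cl)cc2)c1/C=N/OCc1ccc(C(=O)OC(C)(C)C)cc1` gives 0.1 ug/mL. The step of a 3.6-fold higher number from compound 1 to compound 3 (0.56 log units; beyond the scatter) and the step of a 59-fold higher number from compound 2 to compound 3 (1.77 log units; beyond the scatter) both run toward higher numbers when 1H-imidazol-1-yl enters; the step of a 16-fold lower number from compound 1 to compound 2 (1.21 log units; beyond the scatter) shows the widest spread within the measured set.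

Compound 4 `Cc1nn(C)c(N(C)C)c1/C=N/OCc1ccc(C(=O)OC(C)(C)C)cc1` differs from compound 3 in one place: dimethylamino in place of 1H-imidazol-1-yl on an aromatic carbon. Among the measured compounds shown here, no measured step covers dimethylamino, so the expectation rests on the two steps that leave 1H-imidazol-1-yl, both of which lead to lower numbers than compound 3. The group entering is smaller than any of the three already compared and carries no ring, so a modest step toward a lower number is expected for compound 4 in this assay, not one of the size seen for compound 2.

Compound 4 is therefore estimated at 2.5 ug/mL, within 0.7 ug/mL to 9 ug/mL, meaning an expected step of a 2.4-fold lower number from compound 3 to compound 4 (0.38 log units; beyond the scatter).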

Compound 4, half-maximal inhibitory concentration: 2.76 ug/mL
The estimate for compound 4 lay 1.1-fold (0.04 log units) below the measured number; the measured number falls inside the stated range.
By their numbers in this assay, from the lowest: compound 2; then compounds 1 and 4 (each within the scatter of the next); then compound 3.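

In this assay the ringless dimethylamino group gives a 2.1-fold lower number from compound 3 to compound 4 (0.33 log units; beyond the scatter) and so shows that a lower number than that of the imidazolyl compound does not depend on a ring at this aromatic carbon. The comparison with the pyrrolyl compound gives a 1.7-fold higher number from compound 1 to compound 4 (0.23 log units; within the scatter) and does not separate dimethylamino from 1H-pyrrol-1-yl, although only one of them carries a ring. The 4-chlorophenoxy group stays apart from this new group, with a 28-fold higher number from compound 2 to compound 4 (1.44 log units; beyond the scatter) in the series, and compound 2 alone holds a number beyond the scatter of all three others.

As far as these compounds go, whether the low number of compound 2 needs the chlorine, or the ether oxygen, remains open, as would be tested by an unsubstituted phenoxy, a 4-chloroanilino or a morpholine group at this position. Nothing measured here bears on why these groups differ.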